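The compounds below may be only part of what the source reports. "The series", "measured", "known", "first", "only" and "open" are said of these compounds alone.

Measured in a functional assay on PANC-1 cells (Homo sapiens) for inhibition, read by MTT assay, with a stated time of 24 h, tested at 10 uM; on this read-out lower numbers stand for less inhibition and higher numbers for more inhibition at the one concentration tested (going by the name of the read-out):
compound 1 `CC(C)=CCC/C(C)=C/CC1Cc2c(OCC=C(C)C)cc(=O)n(CCCO)c2CC1(C)C`: 15.9%
compound 2 `CC(C)=CCC/C(C)=C/COc1cc(=O)n(CCCO)c2c1CC(C/C=C(\C)CCC=C(C)C)C(C)(C)C2`: 3.1%
compound 3 `CC(C)=CCC/C(C)=C/CC1Cc2c(OC(=O)Nc3ccc(F)cc3)cc(=O)n(CCCO)c2CC1(C)C`: 6.2%

Compound 3 holds the second highest of the three numbers. Its nearest neighbour is compound 2, with a number 3.1 percentage points higher from compound 2 to compound 3 (within the scatter); the furthest is compound 1, with a number 9.7 percentage points lower from compound 1 to compound 3 (within the scatter). Compound 4 `CC(C)=CCC/C(C)=C/CC1Cc2c(OC(=O)Nc3ccc(F)cc3F)cc(=O)n(CCCO)c2CC1(C)C` is the next step: fluoro in place of hydrogen on an aromatic carbon. Going by the values given here, no measured step concerns a fluoro for hydrogen on that ring; the steps that touch the same part of the molecule, a number 9.7 percentage points lower from compound 1 to compound 3 (within the scatter) and a number 3.1 percentage points higher from compound 2 to compound 3 (within the scatter), stay within the scatter, and only a number 12.8 percentage points lower from compound 1 to compound 2 (beyond the scatter) moves beyond it. No step beyond the scatter is therefore expected in this assay. Compound 4 is expected to give about 7%, between 0% and 17%, which means an expected a number 0.8 percentage points higher from compound 3 to compound 4 (within the scatter).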

Compound 4, a percentage reported as inhibition, at one concentration (the size of the read-out at that concentration, not a potency): 15.6%
Compound 4: middle estimate off by 8.6 percentage points, on the low side, and the stated range covers the measured number.
By their numbers in this assay, from the lowest: compounds 2, 3, 4 and 1 (each within the scatter of the next, the first and the last beyond it).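

In this assay, fluoro on an aromatic carbon, ortho to a large group, gives a number 9.4 percentage points higher from compound 3 to compound 4 (within the scatter), so the only change shown on this ring does not separate the two compounds. With (2,4-difluorophenyl)carbamoyl on the oxygen, the comparisons read a number 0.3 percentage points lower from compound 1 to compound 4 (within the scatter) and a number 12.5 percentage points higher from compound 2 to compound 4 (beyond the scatter), and only the latter passes the scatter. Nothing available explains these steps. Open remain other groups on that aromatic carbon, such as chloro or methoxy, and whether a full concentration series would separate these compounds.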